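Nitrile-to-carboxylic-acid exchange at the chain terminus

The source may hold more compounds than are shown below. What is called first, only, known or untested is meant among the compounds shown, and "the series" means these compounds.

Compound 3 `CCc1cc(C(C)=O)c(O)cc1OCCCCCCC(C)(C)C#N` has the lowest number of the three measured in an assay on isolated protein for inhibition of leukotriene B4 receptor 1 (Homo sapiens), tested at 10 uM; a higher number here means more inhibition at the concentration tested (going by the name of the read-out), a lower number less inhibition: compound 3 gives 65%. Compound 1 `CCc1cc(C(C)=O)c(O)cc1OCCCCC#N` gives 92% and compound 2 `CCc1cc(C(C)=O)c(O)cc1OCCCCC(C)(C)C#N` gives 79%. The measured steps are a number 13 percentage points lower from compound 1 to compound 2 (beyond the scatter), a number 27 percentage points lower from compound 1 to compound 3 (beyond the scatter) and a number 14 percentage points lower from compound 2 to compound 3 (beyond the scatter), all beyond the scatter and all pointing the same way: the longer the chain carrying the nitrile, the lower the number.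

Compound 4 `CCc1cc(C(C)=O)c(O)cc1OCCCC(C)(C)C(=O)O` is unmeasured. It differs from compound 3 as follows: 1-carboxy-1-methylethyl in place of 4-cyano-4-methylpentyl on a saturated chain carbon, three bonds along the chain from an oxygen on an aromatic ring. Among the compounds with values here, the chain is shorter than in compound 3, which is the direction that gave higher numbers in the steps above, but no measured step exchanges a nitrile for a carboxylic acid, so that part of the change has no precedent. The shortening steps suggest a rise; the acid is an unknown.

An upward step is expected, estimated as a number 10 percentage points higher from compound 3 to compound 4 (within the scatter), on the strength of the chain-length steps but with a wide range. Compound 4 is therefore expected to give about 75% in this assay, between 45% and 95%.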

Compound 4, a percentage reported as inhibition, at one concentration (the size of the read-out at that concentration, not a potency): 89%
Estimate against measurement, compound 4: 14 percentage points below; low and high end bracket the measured number.
By their numbers in this assay, from the lowest: compound 3; then compounds 2, 4 and 1 (each within the scatter of the next, the first and the last beyond it).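

In this assay, within the data shown here, 1-carboxy-1-methylethyl on a saturated chain carbon, three bonds along the chain from an oxygen on an aromatic ring, retains a high number, and replacing 4-cyano-4-methylpentyl gives the one large step here (a number 24 percentage points higher from compound 3 to compound 4 (beyond the scatter)). Against the two shorter nitriles, the steps (a number 10 percentage points higher from compound 2 to compound 4 (within the scatter); a number 3 percentage points lower from compound 1 to compound 4 (within the scatter)) leave compound 4 not distinguishable from compound 2 or compound 1, so a carboxylic acid, absent from the earlier compounds, can stand in this region of the chain without a loss beyond the scatter relative to those nitriles. Nothing at hand accounts for how the acid compares with the nitriles.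

Going by these compounds, the step from compound 3 to compound 4 changes chain length and end group together, so the share of each stays open; a nitrile on the chain of compound 4, or a carboxylic acid on the longer chain of compound 3, would separate them. Also open, on these data alone, are the part played by the two methyl groups beside the acid, which an unbranched carboxylic acid would address, and whether a primary amide or a tetrazole at the same place behaves like the acid.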